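Amide Aryl Variation at the Urotensin-2 Receptor

The source may report more compounds than this note shows. Statements on the series, on what has been measured and on what is new or still open speak of the compounds shown alone.

Three compounds were measured in an assay on HEK293 cells for displacement of a labelled ligand from Urotensin-2 receptor (Homo sapiens), read by fluorescence, with a stated time of 90 min; on this read-out higher numbers stand for weaker inhibition and lower numbers for stronger inhibition.
Compound 1, `O=C(NC1CCN(Cc2ccc(OC3CCNCC3)c(Br)c2)CC1)c1cccs1`, gives 130 nM.
Compound 2, `O=C(NC1CCN(Cc2ccc(OC3CCNCC3)c(Br)c2)CC1)c1ccccn1`, gives 120 nM.
Compound 3, `O=C(NC1CCN(Cc2ccc(OC3CCNCC3)c(Br)c2)CC1)c1cc2cc(Br)ccc2s1`, gives 86 nM.

Compound 3 has the lowest of the three numbers, yet its gaps to the other two fall within the scatter, so no ranking can be read from them. Compound 4, `N#Cc1ccc2cc(C(=O)NC3CCN(Cc4ccc(OC5CCNCC5)c(Br)c4)CC3)sc2c1`, is the untested member; it differs from compound 3 in that (6-cyano-1-benzothiophen-2-yl in place of 5-bromo-1-benzothiophen-2-yl on a carbonyl carbon). Among the compounds with values here, the steps that bear on this position are a 1.5-fold lower number from compound 1 to compound 3 (0.18 log units; within the scatter) and a 1.4-fold lower number from compound 2 to compound 3 (0.14 log units; within the scatter), both within the scatter, so changing the aryl group on the carbonyl carbon has so far produced no step beyond the scatter in this assay. Within the data shown here, no measured pair compares a bromine against a nitrile on this ring. Compound 4 is therefore expected to give about 100 nM in this assay, with a range of 40 nM to 250 nM. The implied step a 1.2-fold higher number from compound 3 to compound 4 (0.07 log units; within the scatter) is expected to stay within the scatter.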

Compound 4, half-maximal inhibitory concentration: 80 nM
Beside the measured number, compound 4's estimate is 1.3-fold (0.10 log units) above it; low and high end bracket the measured number.
By their numbers in this assay, from the lowest: compounds 4, 3, 2 and 1 (each within the scatter of the next).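

The pair that was missing now exists: in this assay the change from 5-bromo-1-benzothiophen-2-yl to 6-cyano-1-benzothiophen-2-yl gives a 1.1-fold lower number from compound 3 to compound 4 (0.03 log units; within the scatter), though the substituent and its ring position change together. The wider steps, a 1.5-fold lower number from compound 2 to compound 4 (0.18 log units; within the scatter) and a 1.6-fold lower number from compound 1 to compound 4 (0.21 log units; within the scatter), also produce no separation, so all four aryl groups on this carbonyl carbon remain indistinguishable. Nothing available explains this insensitivity.

Still open, as far as these compounds go, is whether an amine or a carboxylic acid on the benzothiophene would produce a step beyond the scatter. Also open, from the compounds shown here alone, is how bromine and nitrile compare at one shared ring position.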